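A fluoro for a methyl on the aryl ring of compound 1

The source may report more compounds than this note shows. Statements on the series, on what has been measured and on what is new or still open speak of the compounds shown alone.

Of the compounds shown here, two sharing one core have been measured in an in vitro functional assay on HEK293-A cells for positive allosteric modulation of metabotropic glutamate receptor 5 (Homo sapiens), read by FLIPR and calcium flux; on this read-out lower numbers stand for an effect already at smaller amounts and higher numbers for an effect only at larger amounts of compound. Compound 1 `Cc1cccc(-c2noc(C3CC(=O)N(c4ccc(Cl)c(Cl)c4)C3)n2)c1` gives 390 nM, the lowest of the two numbers; compound 2 `Cc1ccc(N2CC(c3nc(-c4cccc(C)c4)no3)CC2=O)cc1` gives 1300 nM, and the step of a 3.3-fold higher number from compound 1 to compound 2 (0.52 log units; beyond the scatter) is modest. Compound 3 `O=C1CC(c2nc(-c3cccc(F)c3)no2)CN1c1ccc(Cl)c(Cl)c1` differs from compound 1 by fluoro in place of methyl on an aromatic carbon, that is, 3-methylphenyl to 3-fluorophenyl. No measured step touches this ring, so nothing shown speaks for a large shift in either direction. Compound 3 is therefore expected to lie close to compound 1, a step of a 1.3-fold higher number from compound 1 to compound 3 (0.11 log units; within the scatter) within the scatter, with an estimate of 500 nM and a range from 180 nM to 1500 nM.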

Compound 3, half-maximal effective concentration: 3200 nM
The estimate for compound 3 lay 6.4-fold (0.81 log units) below the measured number; measured number above the stated range.
By their numbers in this assay, from the lowest: compound 1; then compound 2; then compound 3.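

The ring carrying the 3-methylphenyl group proves sensitive to a single-atom exchange: in this assay, fluoro in place of methyl on this aromatic carbon gives an 8.2-fold higher number from compound 1 to compound 3 (0.91 log units; beyond the scatter), a step beyond the scatter. The methyl and the fluoro thus cannot be treated as interchangeable at this place on the core of compound 1. No measured evidence bears on what lies behind this difference. The compounds shown leave open how chloro, methoxy or an amine would read at this place. They also leave open whether the 3-fluorophenyl step would hold with 4-methylphenyl on the amide-type nitrogen.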